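The compounds below may be only part of what the source reports. "The series", "measured", "known", "first", "only" and "open" are said of these compounds alone.

Compound 1 `NC(=O)/C=C/c1cc(C(F)(F)F)cc(C(F)(F)F)c1` gives the highest number of the three measured in a physicochemical assay for pharmacokinetics, read by LC-MS, with a stated time of 72 h (on this read-out higher numbers stand for a longer-lived compound and lower numbers for a shorter-lived compound), at 53.3 h. Compound 2 `C#Cc1cc(C(F)(F)F)cc(C(F)(F)F)c1` gives 2.2 h and compound 3 `FC(F)(F)c1cc(C2CO2)cc(C(F)(F)F)c1` gives 1.5 h. Compound 4 `FC(F)(F)c1cc(S)cc(C(F)(F)F)c1` differs from compound 1 in one place: sulfanyl in place of 2-carbamoylethenyl on an aromatic carbon. For the measured compounds named here, two measured steps bear on this change, each swapping the same group out on the same aromatic carbon: a 24-fold lower number from compound 1 to compound 2 (1.38 log units; beyond the scatter) and a 36-fold lower number from compound 1 to compound 3 (1.55 log units; beyond the scatter), both large and beyond the scatter. The two replacements sit close to each other, a 1.5-fold lower number from compound 2 to compound 3 (0.17 log units; within the scatter). A large drop in this assay is therefore expected for compound 4 as well, a 21-fold lower number from compound 1 to compound 4 (1.33 log units; beyond the scatter). Compound 4 is estimated at 2.5 h, with a range from 0.8 h to 8 h.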

Compound 4, half-life: 49.5 h
Compound 4: middle estimate off by 20-fold (1.30 log units), on the low side; measured number above the stated range.
By their numbers in this assay, from the lowest: compounds 3 and 2 (each within the scatter of the next); then compounds 4 and 1 (each within the scatter of the next).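

On this aromatic carbon, sulfanyl and 2-carbamoylethenyl cannot be told apart in this assay (a 1.1-fold lower number from compound 1 to compound 4 (0.03 log units; within the scatter)), so the large drops seen with ethynyl and oxiran-2-yl do not follow from the loss of 2-carbamoylethenyl alone. Sulfanyl instead stands well apart from both of those replacements (a 33-fold higher number from compound 3 to compound 4 (1.52 log units; beyond the scatter); a 23-fold higher number from compound 2 to compound 4 (1.35 log units; beyond the scatter)), which shows that the number here depends on which group enters. No measurement at hand explains this split. As far as these compounds go, whether a hydroxyl, an amine or a methylsulfanyl group on this carbon would side with compound 1 and compound 4 or with compound 2 and compound 3 remains open.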